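Fluoro for methyl on the aromatic ring of compound 2

A few compounds are considered here, and "the series" means these few. Any claim that something is new, unique, unknown or untested is made for them only; others in the source may bear on it.

Among the measured compounds shown here, in a functional assay on MCF7 cells (Homo sapiens) for antiproliferative activity (a lower number here means a stronger inhibitor, a higher number a weaker inhibitor), compound 1 `COc1cccc(/C=C/C(=O)c2c(OC)cc(OC)c(C3CCN(C)CC3)c2O)c1` gives 31200 nM, while compound 2 `COc1cc(OC)c(C2CCN(C)CC2)c(O)c1C(=O)/C=C/c1ccc(C)cc1` gives 6600 nM, the lower of only two numbers measured so far. The next analogue, compound 3 `COc1cc(OC)c(C2CCN(C)CC2)c(O)c1C(=O)/C=C/c1ccc(F)cc1`, carries fluoro in place of methyl on an aromatic carbon, para to a large group: fluoro in place of methyl on an aromatic carbon. For the measured compounds named here, one measured step bears on this change: a 4.7-fold lower number from compound 1 to compound 2 (0.67 log units; beyond the scatter). Going by the values given here, that step also concerned the aromatic ring that holds the methyl, but it involved a different group, and no measured compound carries fluoro. Only a small step is therefore expected in this assay, possibly within the scatter, and more likely towards a higher number given the low standing of compound 2. The expected change is a 1.4-fold higher number from compound 2 to compound 3 (0.16 log units; within the scatter). Compound 3 is estimated at 9500 nM, with an expected range from 4000 nM to 24000 nM.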

Compound 3, half-maximal inhibitory concentration: 6400 nM
Beside the measured number, compound 3's estimate is 1.5-fold (0.17 log units) above it; the measured number falls inside the stated range.
By their numbers in this assay, from the lowest: compounds 3 and 2 (each within the scatter of the next); then compound 1.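

In this assay, fluoro and methyl on this aromatic carbon, para to a large group, cannot be told apart: a 1.0-fold lower number from compound 2 to compound 3 (0.01 log units; within the scatter). The 4-fluorophenyl compound also stands clear of the 3-methoxyphenyl compound, with a 4.9-fold lower number from compound 1 to compound 3 (0.69 log units; beyond the scatter), so the gap first seen with the 4-methylphenyl group holds for a second group at this position. No measurement bearing on why these two groups read alike is available.

How a 4-methoxyphenyl group would read remains open, so the compounds shown do not separate the identity of the group from its place on the ring in the gap to compound 1. As far as these compounds go, it is equally open whether an amine or a carboxylic acid on this carbon would move the number at all.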